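This account rests on a few compounds, and the source may have more. Where it says the series, first, only, none or still open, it means among the compounds named here.

Compound 1 `CCC1C(=O)N(C)c2cnc(Nc3ccc(S(=O)(=O)NCCO)cc3)nc2N1c1ccn(C)n1`: "not active" (no number reported)
Compound 2 `CC[C@@H]1C(=O)N(C)c2cnc(Nc3ccc(S(=O)(=O)Nc4ccccc4)cc3)nc2N1C1CCCC1`: 6000 nM
Compound 3 `CCCCNC(=O)c1ccc2c(ccn2-c2ncc3c(n2)N(c2ccn(C)n2)C(CC)C(=O)N3C)c1`: 12000 nM

These three compounds were tested in a functional assay on NCI-H1975 cells (Homo sapiens) for antiproliferative activity, read by CCK-8 assay, with a stated time of 72 h (a higher number here means a weaker inhibitor of growth, a lower number a stronger inhibitor of growth), and only two of them returned a number. Compound 1 stands at the bottom of the series in one sense only: its result is "not active" (no number reported) in this test, which gives a verdict and no figure to measure against. Compound 2 gives 6000 nM and compound 3 gives 12000 nM in the same test, and those two values lie within the usual scatter of each other.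

Compound 4 `CCC1C(=O)N(C)c2cnc(Nc3ccc(S(N)(=O)=O)cc3)nc2N1c1ccn(C)n1` has not yet been measured. The change from compound 1 is hydrogen in place of 2-hydroxyethyl on a sulfonamide nitrogen and nothing else in the structure differs. Going by the values given here, no measured pair in this small set shows what such a change does, so any expectation here is loose. A modest step toward stronger growth inhibition is expected, landing near the values of the two compounds that have numbers, though compound 4 could also turn out to have no number at all. For compound 4 the estimated value is 4000 nM with an expected range from 500 nM to 25000 nM as the likely span.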

Compound 4, concentration for 50% growth inhibition: "not active" (no number reported)
Compound 4: no number reported, and the estimate cannot be compared.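

Compound 1 and compound 4 both come back without a number, so no step can be read between them in this assay. Nothing shown here offers an explanation for this result. The compounds shown leave open whether hydrogen in place of 2-hydroxyethyl on a sulfonamide nitrogen changes growth inhibition at all.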